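This account rests on a few compounds, and the source may have more. Where it says the series, first, only, none or still open, it means among the compounds named here.

Measured so far in a functional assay on HT-29 cells (Homo sapiens) for antiproliferative activity, read by MTT assay, with a stated time of 48 h; a higher number here means a weaker inhibitor of growth, a lower number a stronger inhibitor of growth:
- compound 1 (`COC(=O)N1N=C(c2ccccc2)CC1c1cc(OC)c(OC)c(OC)c1`): 6260 nM
- compound 2 (`CCOc1cccc(C2=NN(C(=O)OC)C(c3cc(OC)c(OC)c(OC)c3)C2)c1`): 4450 nM

Going by the values given here, of these two numbers, the one for compound 2 cannot be ranked against the one for compound 1, since the two lie within the scatter of each other. The next structure is compound 3 (`COC(=O)N1N=C(c2cccc(C)c2)CC1c1cc(OC)c(OC)c(OC)c1`), which differs from compound 2 by methyl in place of ethoxy on an aromatic carbon. Among the compounds with values here, the one measured step bearing on this is a 1.4-fold lower number from compound 1 to compound 2 (0.15 log units; within the scatter) and it puts ethoxy in place of hydrogen on an aromatic carbon, staying within the scatter. Within the data shown here, with only that step to go on, no shift beyond the scatter is expected in this assay in either direction. The estimated step is a 1.1-fold higher number from compound 2 to compound 3 (0.05 log units; within the scatter) and it is expected to stay within the scatter. For compound 3 the estimated value is 5000 nM within an expected range of 2200 nM to 11000 nM.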

Compound 3, concentration for 50% growth inhibition: 100 nM
Estimate against measurement, compound 3: 50-fold (1.70 log units) above; measured number outside the range, below it.
By their numbers in this assay, from the lowest: compound 3; then compounds 2 and 1 (each within the scatter of the next).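

Until now this aromatic carbon looked indifferent in this assay, since hydrogen and ethoxy there gave numbers within the scatter of each other. Methyl breaks that picture, with a 45-fold lower number from compound 2 to compound 3 (1.65 log units; beyond the scatter) on replacing ethoxy and a 63-fold lower number from compound 1 to compound 3 (1.80 log units; beyond the scatter) on replacing hydrogen, so the response does not follow a steady trend with group size: methyl, with its single heavy atom, lies in size between hydrogen and the three heavy atoms of ethoxy, yet its number stands apart from both. Nothing available here accounts for this sharp effect.

As far as these compounds go, whether the effect is particular to methyl remains open, and an ethyl chain, a methoxy group or a chlorine atom on the same carbon would show how narrow it is. From the compounds shown here alone, whether it extends to other cell lines also remains open.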